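Methylating the Bridging Nitrogen: Does the Step Carry Over?

The source may hold more compounds than are shown below. What is called first, only, known or untested is meant among the compounds shown, and "the series" means these compounds.

Compound 1 `COc1cccc(Nc2ccc(NC(=O)C3CC3)cc2)c1` is the starting point of this comparison. In an assay on isolated protein for binding affinity to melatonin receptor type 1B (Homo sapiens) (a lower number here means a stronger inhibitor, a higher number a weaker inhibitor), compound 1 gives 64 nM. Compound 2 `COc1cccc(N(C)c2ccc(NC(=O)C3CC3)cc2)c1` differs from it by methyl in place of hydrogen on a nitrogen on an aromatic ring, and in this assay compound 2 gives 4.8 nM. The result is a 13-fold lower number from compound 1 to compound 2 (1.12 log units; beyond the scatter).

Compound 3 `CCCC(=O)Nc1ccc(Nc2cccc3c2CCO3)cc1` is built on a different core; the difference between the two cores is not broken down here. In this assay compound 3 gives 39 nM, a number within the scatter of that of compound 1 and well apart from that of compound 2.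

Compound 4 `CCCC(=O)Nc1ccc(N(C)c2cccc3c2CCO3)cc1` has not yet been measured. It differs from compound 3 by methyl in place of hydrogen on a nitrogen on an aromatic ring, the same change, at the same kind of place, as the one from compound 1 to compound 2; the change occurs twice among these four compounds. Within the data shown here, the step from compound 3 to compound 4 is expected to be a 7.8-fold lower number from compound 3 to compound 4 (0.89 log units; beyond the scatter) in this assay, set a little more cautiously than the measured step because a 13-fold lower number from compound 1 to compound 2 (1.12 log units; beyond the scatter) is the only precedent and it stands on a different core. Compound 4 is therefore estimated at 5 nM in this assay, with a likely range from 2 nM to 15 nM.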

Compound 4, inhibition constant: 0.49 nM
The estimate for compound 4 lay 10-fold (1.01 log units) above the measured number, and the stated range ends above it.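

In this assay, the same change on the second core gave an 80-fold lower number from compound 3 to compound 4 (1.90 log units; beyond the scatter). The direction of the step carried over from one core to the other, but its size did not: the same change on two cores in this assay, a 13-fold lower number (1.12 log units; beyond the scatter) from compound 1 to compound 2 and an 80-fold lower number (1.90 log units; beyond the scatter) from compound 3 to compound 4, 6.0-fold (0.78 log units) apart, beyond the scatter of two such steps. These two pairs show that placing methyl on this nitrogen lowered the number on both cores shown, but they do not show how large the step would be on a further core, and they do not reveal which of the differences between the two cores goes with the gap between the steps.

The compounds shown leave open how an ethyl group or a longer chain on that nitrogen would compare with methyl, since methyl is the only group other than hydrogen seen there. They also leave open whether the step would persist if an amine or a carboxylic acid were carried on the amide chain.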